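The source may hold more compounds than are shown below. What is called first, only, known or untested is meant among the compounds shown, and "the series" means these compounds.

Measured so far in a functional assay on MDA-MB-231 cells (Homo sapiens) for antiproliferative activity, read by sulforhodamine B assay; on this read-out lower numbers stand for stronger inhibition of growth and higher numbers for weaker inhibition of growth:
compound 1 `CC1CC(=O)c2s/c(=N/c3ccccc3)oc2C1` gives 2310 nM
compound 2 `CC(C)C1CC(=O)c2s/c(=N/c3ccccc3)oc2C1` gives 2480 nM
compound 3 `CC1(C)CC(=O)c2s/c(=N/c3ccc(Cl)cc3)oc2C1` gives 6380 nM

Compound 3 stands highest of the three numbers in this assay; its gap to compound 2 and to compound 1 lies beyond the scatter in each case. Compound 4 `CC1CC(=O)c2s/c(=N/c3ccc(Cl)cc3)oc2C1` follows from compound 3 by hydrogen in place of methyl on a saturated ring carbon. The one measured step at this saturated ring carbon, a 1.1-fold higher number from compound 1 to compound 2 (0.03 log units; within the scatter), swapped one alkyl group for a larger one and stayed within the scatter, so the size of the alkyl substituent at this position has so far shown no effect in this assay. Within the data shown here, compound 1 carries the same single methyl as compound 4 but a different aryl group, and no single step connects it to compound 3; its number in this assay is simply lower than that of compound 3. On this basis the step of a 1.4-fold lower number from compound 3 to compound 4 (0.15 log units; within the scatter) is expected to stay within the scatter, with some allowance toward the lower numbers of compound 1 and compound 2. Compound 4 is therefore estimated at 4500 nM in this assay, with a range from 1800 nM to 11000 nM.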

Compound 4, concentration for 50% growth inhibition: 14300 nM
Estimate against measurement, compound 4: 3.2-fold (0.50 log units) below; measured number outside the range, above it.
By their numbers in this assay, from the lowest: compounds 1 and 2 (each within the scatter of the next); then compound 3; then compound 4.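

At the saturated ring carbon, the number of alkyl groups appears to matter where their size did not: in this assay, the loss of one methyl gives a 2.2-fold higher number from compound 3 to compound 4 (0.35 log units; beyond the scatter), whereas the swap of methyl for isopropyl, a 1.1-fold higher number from compound 1 to compound 2 (0.03 log units; within the scatter), stayed within the scatter. Among these compounds, the aromatic carbon is the more sensitive place so far, as chloro in place of hydrogen gives a 6.2-fold higher number from compound 1 to compound 4 (0.79 log units; beyond the scatter), a larger step toward weaker inhibition of growth. Nothing at hand gives a reason for either step.

Going by these compounds, it remains open whether the chloro step carries over to a core with two methyl groups on the saturated ring carbon, so the two changes cannot yet be judged together. Also open, on these data alone, is how a hydroxyl, an amine or a longer chain would behave at the saturated ring carbon, and how a methoxy or a nitrile would compare with chloro on the aromatic carbon.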